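Series notes: the step from compound 3 to compound 4

This account rests on a few compounds, and the source may have more. Where it says the series, first, only, none or still open, it means among the compounds named here.

Measured so far in an ADME assay on A549 cells (Homo sapiens) for cytotoxicity, read by LDH release, with a stated time of 15 h (a lower number here means that less compound is tolerated, a higher number that more compound is tolerated), for three compounds:
- compound 1 `O=C(Nc1ccc(NCc2cc(C(F)(F)F)cc(C(F)(F)F)c2)cc1Cl)c1cc(Cl)ccc1O` gives 22900 nM
- compound 2 `CC(C)(C)OC(=O)N1CCC(CNc2ccc(NC(=O)c3cc(Cl)ccc3O)c(Cl)c2)CC1` gives "not determined" (no result reported)
- compound 3 `O=C(Nc1ccc(NCc2ccc(F)cc2)cc1Cl)c1cc(Cl)ccc1O` gives "not determined" (no result reported)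

Compound 3 therefore has no number on this scale, and neither does compound 2. Only compound 1 carries a value. Going by the values given here, the series offers no measured step between any two compounds, so the effect of a change on this nitrogen cannot be read from the data.

Compound 4 `CCCCCCC(C)Nc1ccc(NC(=O)c2cc(Cl)ccc2O)c(Cl)c1` has not yet been measured in this assay and differs from its neighbour by one substitution. The step 1-methylheptyl in place of 4-fluorobenzyl on a nitrogen on an aromatic ring puts 1-methylheptyl, with no ring, in place of 4-fluorobenzyl on a nitrogen on an aromatic ring. With no value for compound 3, no direction or size can be assigned to this step itself. The expectation rests on compound 1 alone (22900 nM), which shares the core but carries a different group on that nitrogen. Compound 4 is expected to fall in the same region, with no difference beyond the usual scatter, though a single reference value leaves the uncertainty wide. For compound 4 the estimated half-maximal cytotoxic concentration is 18000 nM with an expected range of 6000 nM to 50000 nM in this estimate.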

Compound 4, half-maximal cytotoxic concentration: 18600 nM
Compound 4: middle estimate off by 1.0-fold (0.01 log units), on the low side; the range from low to high includes it.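

In this assay, going by these compounds alone, compound 4 gives 18600 nM but compound 3 has no single number, so no step between compound 3 and compound 4 can be read. No available evidence bears on this result.
The compounds shown leave open how replacing 4-fluorobenzyl with 1-methylheptyl on this nitrogen changes the tolerated concentration.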